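A few compounds are considered here, and "the series" means these few. Any claim that something is new, unique, unknown or untested is made for them only; others in the source may bear on it.

Measured in a functional assay on HCT-116 cells (Homo sapiens) for inhibition, read by CCK-8 assay, with a stated time of 72 h, tested at 8 uM; on this read-out lower numbers stand for less inhibition of growth and higher numbers for more inhibition of growth at the one concentration tested
Compound 1 `Nc1ccccc1NC(=O)/C=C/c1ccc(CSc2ccc(Cl)cc2)cc1` gives 3.27%
Compound 2 `Nc1ccccc1NC(=O)/C=C/c1ccc(CSc2cccc(F)c2)cc1` gives 3.22%
Compound 3 `COc1ccc(SCc2ccc(C(=O)Nc3ccccc3N)cc2)cc1` gives 90.1%

Compound 2 sits with compound 1 at the low end of these three numbers, the two level within the scatter, while compound 3 lies far higher. The change to compound 4 `Nc1ccccc1NC(=O)/C=C/c1ccc(CSc2ccc(F)cc2)cc1` is 4-fluorophenyl in place of 3-fluorophenyl on a sulfur. Going by the values given here, the one measured step at this place is a number 0.1 percentage points lower from compound 1 to compound 2 (within the scatter), and it is small. Among the compounds with values here, compound 3 differs in more than this place and offers no step to lean on. In this assay no step beyond the scatter is therefore expected. The expected change is a number 0.8 percentage points higher from compound 2 to compound 4 (within the scatter). Compound 4 is estimated at 4%, with an expected range of 0% to 13%.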

Compound 4, percent growth inhibition at one concentration: 20.2%
For compound 4 the middle estimate is 16.2 percentage points below the measured one; the whole stated range lies below it.
By their numbers in this assay, from the lowest: compounds 2 and 1 (each within the scatter of the next); then compound 4; then compound 3.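

In this assay the group on a sulfur is not silent: 4-fluorophenyl in place of 3-fluorophenyl gives a number 17 percentage points higher from compound 2 to compound 4 (beyond the scatter), a modest step beyond the scatter. Fluoro in place of chloro on an aromatic carbon gives a number 16.9 percentage points higher from compound 1 to compound 4 (beyond the scatter), so the identity of the halogen can count as well as where it sits. Nothing measured here bears on the origin of either step.

From the compounds shown here alone, whether an amine or a carboxylic acid in place of fluoro on an aromatic carbon moves the number further stays open. The much higher number of compound 3 cannot be tied to any single place.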